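Shortening the amide-bearing chain on compound 3

This account rests on a few compounds, and the source may have more. Where it says the series, first, only, none or still open, it means among the compounds named here.

Compound 3 `CCC(Oc1ccc2c(c1)S(=O)(=O)N=C(c1c(O)c(-c3cccs3)nn(CCC(C)C)c1=O)N2)C(N)=O` holds the highest number of the three compounds measured in an in vitro ADME assay on microsomes from liver (Homo sapiens) for metabolic stability, tested at 5 uM; on this read-out lower numbers stand for a shorter-lived compound and higher numbers for a longer-lived compound: compound 3 gives 0.35 h. Compound 1 `CC(C)CCn1nc(-c2cccs2)c(O)c(C2=NS(=O)(=O)c3ccccc3N2)c1=O` is nearest, and in this assay compound 1 gives 0.2 h, a gap within the scatter; compound 2 `CC(C)CCn1nc(-c2cccs2)c(O)c(C2=NS(=O)(=O)c3cc(O)ccc3N2)c1=O` is furthest, and in this assay compound 2 gives 0.0933 h. Compound 4 `CC(C)CCn1nc(-c2cccs2)c(O)c(C2=NS(=O)(=O)c3cc(CCC(N)=O)ccc3N2)c1=O` differs from compound 3 in one place: 2-carbamoylethyl in place of 1-carbamoylpropoxy on an aromatic carbon.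

Going by the values given here, three measured steps bear on this change. Adding the 1-carbamoylpropoxy group gave a 1.8-fold higher number from compound 1 to compound 3 (0.24 log units; within the scatter). Capping the hydroxy with the 1-carbamoylpropyl gave a 3.8-fold higher number from compound 2 to compound 3 (0.57 log units; beyond the scatter). Putting a hydroxy onto the aromatic carbon gave a 2.1-fold lower number from compound 1 to compound 2 (0.33 log units; beyond the scatter). Among the compounds with values here, compound 4 carries a 2-carbamoylethyl group on that aromatic carbon and no oxygen there, so no measured step covers it directly; the small step that adding the full chain made in this assay suggests that removing the oxygen link and shortening the chain will move the number little. The step from compound 3 to compound 4 in this assay is therefore expected to be a 1.4-fold lower number from compound 3 to compound 4 (0.15 log units; within the scatter). For compound 4 in this assay the estimated half-life is 0.25 h, with a likely range from 0.1 h to 0.6 h.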

Compound 4, half-life: > 1 h
Compound 4: only a limit was reported; the forecaster's own chance of this, stated with the estimate: 5%; middle value at least 4.0-fold (0.60 log units) away from the limit.
By their numbers in this assay, from the lowest: compound 2; then compounds 1 and 3 (each within the scatter of the next). At a limit, above all of these: compound 4.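

Compound 4 gives a limit of the assay and not a number: the limit of > 1 h in this assay, at which 1 of the 4 values shown sits.
Even so, in this assay the 2-carbamoylethyl group in place of 1-carbamoylpropoxy gave an at least 2.8-fold higher number from compound 3 to compound 4 (0.45 log units; beyond the scatter), so this aromatic carbon tells the two amide-bearing chains apart, which the step within the scatter on adding 1-carbamoylpropoxy to the unsubstituted core had not suggested. Set against the simpler substituents at the same carbon, the 2-carbamoylethyl group gave an at least 5.0-fold higher number from compound 1 to compound 4 (0.69 log units; beyond the scatter) in place of hydrogen and an at least 10-fold higher number from compound 2 to compound 4 (1.03 log units; beyond the scatter) in place of hydroxy, so this position, where the earlier steps were modest at most, can carry a large change in half-life.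

Going by these compounds, how far compound 4 lies past its limit stays open, and each of these three steps therefore has a lower bound but no upper one. The change from compound 3 to compound 4 also removes the ether oxygen and alters the carbon chain together, and the compounds shown do not separate the two, nor do they show whether a carboxylic acid, an amine or a longer chain in place of the 2-carbamoylethyl group would keep the compound as long-lived.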